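Methyl for trifluoromethyl: a step from an inactive compound

The compounds below may be only part of what the source reports. "The series", "measured", "known", "first", "only" and "open" are said of these compounds alone.

Measured so far:
compound 1 `CNC(=O)c1sc(N2CC3CC2(CNC(=O)c2c[nH]c4ncc(C(F)(F)F)cc24)C3)nc1C(F)(F)F`: > 100000 nM
compound 2 `C[C@@H]1CN(c2cnc(Nc3cc(F)c(OCC4CC4)c(F)c3)nc2NC2CCOCC2)CCN1`: 251 nM

In an assay on isolated protein for inhibition of tyrosine-protein kinase receptor TYRO3 (Homo sapiens), read by LC-MS, with stated times of 30 min and 180 min (a lower number here means a stronger inhibitor, a higher number a weaker inhibitor), compound 1 gives only a limit, > 100000 nM, not a number. Compound 1 therefore sits at the limit of > 100000 nM in this assay, at which 1 of the 2 values shown sits. Among the measured compounds shown here, compound 2 gives 251 nM in this assay, the one real number in the set. Compound 3 `CNC(=O)c1sc(N2CC3CC2(CNC(=O)c2c[nH]c4ncc(C)cc24)C3)nc1C(F)(F)F` differs from compound 1 by methyl in place of trifluoromethyl on an aromatic carbon. For the measured compounds named here, no measured pair shows what this change does. The step of an at least 1.2-fold lower number from compound 1 to compound 3 (0.09 log units; that floor lies within the scatter) is expected to be small, with compound 3 likely remaining near the limit. Compound 3 is estimated at 80000 nM, with a range from 8000 nM to 300000 nM.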

Compound 3, half-maximal inhibitory concentration: 1000 nM
For compound 3 the middle estimate is 80-fold (1.90 log units) above the measured one; measured number below the stated range.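

On this aromatic carbon, methyl in place of trifluoromethyl gives an at least 100-fold lower number from compound 1 to compound 3 (2.00 log units; beyond the scatter) in this assay. Among the compounds shown here, the earlier compounds held no pair that varied this position, and this pair shows that the core of compound 1 can give a measurable value when only this group changes. The true size of the step remains unknown, as compound 1 gives a limit and not a number: the limit of > 100000 nM in this assay, at which 1 of the 3 values shown sits.

With a single pair, no trend across substituents at this carbon can be read. As far as these compounds go, how hydrogen, chlorine, ethyl or methoxy would compare with methyl here remains open.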